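A Methyl Group on the Benzyl of Compound 2

This account rests on a few compounds, and the source may have more. Where it says the series, first, only, none or still open, it means among the compounds named here.

- Compound 1 `COc1ccc(S(=O)(=O)Nc2cccc(/C=C(\C#N)C(=O)Nc3nnc(-c4cccs4)s3)c2)cc1` gives > 20000 nM
- Compound 2 `COc1ccc(S(=O)(=O)Oc2ccccc2/C=C(\C#N)C(=O)Nc2nnc(Cc3ccccc3)s2)cc1` gives > 50000 nM

Both values come from an ADME assay on HEK-293T cells (Homo sapiens) for inhibition, read by CCK-8 assay, with a stated time of 48 h (a lower number here means a stronger inhibitor, a higher number a weaker inhibitor), and neither is a number. Compound 1 is known only by its limit of > 20000 nM. Compound 2 likewise stands only at a limit, > 50000 nM.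

Compound 3 `COc1ccc(S(=O)(=O)Oc2ccccc2/C=C(\C#N)C(=O)Nc2nnc(Cc3ccc(C)cc3)s2)cc1` carries methyl in place of hydrogen on an aromatic carbon, para to a large group, turning benzyl to 4-methylbenzyl (methyl in place of hydrogen on an aromatic carbon). For the measured compounds named here, no measured pair shows this change, so no step beyond the scatter is expected in this assay. The estimated step is a number no higher from compound 2 to compound 3 (the limit leaves the size open). Compound 3 is expected at 50000 nM, with an estimated range of 20000 nM to 100000 nM.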

Compound 3, half-maximal inhibitory concentration: > 50000 nM
Compound 3: no number, only a limit; the forecaster's own chance of this, stated with the estimate: 75%; the middle value lies on the limit itself.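

In this assay compound 3 gives > 50000 nM, a limit and not a number. Compound 2 also stands only at a limit, so no step can be read between compound 2 and compound 3. The compounds shown leave open whether the change from benzyl to 4-methylbenzyl alters inhibition at all.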